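This account rests on a few compounds, and the source may have more. Where it says the series, first, only, none or still open, it means among the compounds named here.

Working notes on a small indole-thioether series tested in a functional assay on the whole organism with Mus musculus as the target, in the writhing test; on this read-out higher numbers stand for an effect only at larger amounts of compound and lower numbers for an effect already at smaller amounts.

Compound 1 `Cc1[nH]c2ccc(Cl)cc2c1SC1CCNCC1` gives 0.8 mg/kg in this assay. Compound 2 `Cc1[nH]c2ccc(Br)cc2c1SC1CCNCC1` gives 0.7 mg/kg in this assay. The change between the two is bromo in place of chloro on an aromatic carbon. The step made by that change is a 1.1-fold lower number from compound 1 to compound 2 (0.06 log units; within the scatter), and it lies within the scatter of the method.

Compound 3 `CN1CCC(Sc2cn(C)c3ccc(Cl)cc23)CC1` is built on a different core; the difference between the two cores is not broken down here. In this assay compound 3 gives 3.9 mg/kg, the highest number of the three measured, and its distance from compound 1 as well as from compound 2 is beyond the scatter.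

Compound 4 `CN1CCC(Sc2cn(C)c3ccc(Br)cc23)CC1` has not yet been measured in this assay. It differs from compound 3 by bromo in place of chloro on an aromatic carbon. The place of this change is described in the same words as for the pair compound 1 and compound 2, so it is the same change, made on the other core; among the compounds here it occurs twice in all, once measured and once not.

Going by the values given here, because the only measured instance of this change is a 1.1-fold lower number from compound 1 to compound 2 (0.06 log units; within the scatter), the step expected in this assay is a 1.1-fold lower number from compound 3 to compound 4 (0.05 log units; within the scatter), of the same small size as the earlier one. Compound 4 is therefore estimated to give 3.5 mg/kg in this assay, with a range from 1.8 mg/kg to 7 mg/kg. The measured number for compound 4 is awaited.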

Compound 4, dose for half-maximal effect: 5.4 mg/kg
Compound 4: middle estimate off by 1.5-fold (0.19 log units), on the low side, within the range that was stated.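

In this assay, bromo in place of chloro on an aromatic carbon gives a 1.4-fold higher number from compound 3 to compound 4 (0.14 log units; within the scatter), so on this second core too the step stays small. Set beside the earlier step, the change carries across the two cores with no difference that can be told from the scatter: the same change on two cores in this assay, a 1.1-fold lower number (0.06 log units; within the scatter) from compound 1 to compound 2 and a 1.4-fold higher number (0.14 log units; within the scatter) from compound 3 to compound 4, 1.6-fold (0.20 log units) apart, within the scatter of two such steps. Going by these compounds alone, this supports treating chloro and bromo at this place as interchangeable in this read-out for these two cores, but it rests on only two pairs, neither with a step beyond the scatter, so it does not show that the change would carry to any other core, nor does it show whether a real small step is hidden within the scatter.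

The compounds shown leave open whether a group other than the two halogens on this aromatic carbon, such as fluoro, methoxy or a nitrile, would give a step beyond the scatter, and whether such a step would then carry from one core to the other. They also leave open which of the differences between the core of compound 1 and the core of compound 3 goes with the distance between their numbers, and what an ethyl group or a longer chain would do in place of a methyl group of compound 3.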